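Pyrazolyl to pyridazinyl on the quinolone carboxamide core

The compounds below may be only part of what the source reports. "The series", "measured", "known", "first", "only" and "open" are said of these compounds alone.

Compound 1 `NC(=O)c1cn(-c2ccc(O)cc2F)c2cc(-c3ccncc3)ccc2c1=O`: 7000 nM
Compound 2 `NC(=O)c1cn(-c2ccc(O)cc2Cl)c2cc(-n3cccn3)ccc2c1=O`: 600 nM

In an assay on isolated protein for inhibition of Calpain-1 catalytic subunit (Homo sapiens) (a higher number here means a weaker inhibitor, a lower number a stronger inhibitor), compound 2 gives 600 nM, the lower of the two numbers measured. Among the measured compounds shown here, compound 1 gives 7000 nM in this assay, a gap beyond the scatter, but it differs from compound 2 in two places, so no single step is recorded between them. Compound 3 `NC(=O)c1cn(-c2ccc(O)cc2Cl)c2cc(-c3cccnn3)ccc2c1=O` has not yet been measured. It differs from compound 2 in one place: pyridazin-3-yl in place of 1H-pyrazol-1-yl on an aromatic carbon. Compound 1, carrying a six-membered pyridin-4-yl at that position, shows the weaker number, yet it also carries a different halogen, so the step is not isolated. Compound 3 is therefore expected to show a modest weakening, a step of a 2.0-fold higher number from compound 2 to compound 3 (0.30 log units; within the scatter), which may not exceed the scatter. Compound 3 is estimated at 1200 nM in this assay, within a range of 350 nM to 4500 nM.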

Compound 3, half-maximal inhibitory concentration: 2000 nM
Estimate against measurement, compound 3: 1.7-fold (0.22 log units) below; low and high end bracket the measured number.
By their numbers in this assay, from the lowest: compound 2; then compound 3; then compound 1.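

In this assay the change from 1H-pyrazol-1-yl to pyridazin-3-yl gives a 3.3-fold higher number from compound 2 to compound 3 (0.52 log units; beyond the scatter), so the number responds to the ring held on this aromatic carbon, which compound 1 could not show since it differs from compound 2 in two places. A five-membered aromatic ring gives way to a six-membered one, while the hetero atom, donor and acceptor counts stay the same, so those counts alone do not follow the step. Nothing measured here accounts for the step.

As far as these compounds go, it remains open whether another five-membered ring, such as an imidazole or a triazole, or a non-aromatic amine such as morpholine, would match compound 2 at this position. The halogen's separate contribution also stays unresolved, since the fluorine of compound 1 changes alongside its pyridin-4-yl group.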